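This account rests on a few compounds, and the source may have more. Where it says the series, first, only, none or still open, it means among the compounds named here.

In a functional assay on HT-1080 cells (Homo sapiens) for antiproliferative activity, read by sulforhodamine B assay, with a stated time of 48 h (on this read-out lower numbers stand for stronger inhibition and higher numbers for weaker inhibition), compound 1 `CC(=O)Nc1ccc(S(=O)(=O)Oc2ccccc2C(C)C)cc1` gives 12000 nM, and compound 2 `CC(C)c1ccccc1OS(=O)(=O)c1ccc(NC(=O)CCl)cc1` gives 1000 nM. Compound 2 holds the lowest of the two numbers, the other being higher: a 12-fold lower number from compound 1 to compound 2 (1.08 log units; beyond the scatter), a change made by chloro in place of hydrogen on a saturated chain carbon bound to a carbonyl carbon. Compound 3 `CCCCCNC(=O)Nc1ccc(S(=O)(=O)Oc2ccccc2C(C)C)cc1` is not yet measured in this assay. It differs from compound 2 by pentylamino in place of chloromethyl on a carbonyl carbon; cut one bond further out this reads (chloromethyl)carbonyl to pentylcarbamoyl. The change thus takes away the chlorine that alone set compound 2 apart from compound 1, and puts a pentylamino in its place on the carbonyl carbon. Among the measured compounds shown here, the single measured step that bears on it is the large one from compound 1 to compound 2; nothing here shows what a pentylamino on that carbonyl carbon does on its own, so the expectation rests on the loss of the chlorine. Compound 3 is therefore expected to move back toward the number of compound 1, a step of about an 8.0-fold higher number from compound 2 to compound 3 (0.90 log units; beyond the scatter) in this assay. The value of compound 3 is estimated at 8000 nM, with a range from 2500 nM to 25000 nM.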

Compound 3, half-maximal inhibitory concentration: 4700 nM
Compound 3: middle estimate off by 1.7-fold (0.23 log units), on the high side; the range from low to high includes it.
By their numbers in this assay, from the lowest: compound 2; then compound 3; then compound 1.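

Working notes on the carbonyl carbon: in this assay, replacing chloromethyl by pentylamino gives a 4.7-fold higher number from compound 2 to compound 3 (0.67 log units; beyond the scatter) and replacing methyl by pentylamino gives a 2.6-fold lower number from compound 1 to compound 3 (0.41 log units; beyond the scatter). A lower number at this place therefore does not depend on the chlorine alone: pentylamino, which carries no chlorine, also takes the number below that of the methyl compound, though not as far as chloromethyl does, so that the order at this carbon now has three measured points and compound 2 remains the lowest of them. Nothing on hand accounts for either step.

Still open, as far as these compounds go, is whether the lowering seen with pentylamino goes with the length of the pentyl chain or with the amino nitrogen on the carbonyl carbon; a shorter propylamino, a longer octylamino or a plain hexyl chain on that carbon would separate the two. Also open, from the compounds shown here alone, is whether the lead of chloromethyl belongs to chlorine in particular, which a bromomethyl or a fluoromethyl on the same carbon would test.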